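This account rests on a few compounds, and the source may have more. Where it says the series, first, only, none or still open, it means among the compounds named here.

Compound 1, `O=C1C=CC(=O)C(c2cc(-c3ccc(C(=O)N4CCC(C(F)(F)F)CC4)s3)on2)=C1`, gives in a functional assay on A549 cells (Homo sapiens) for cytotoxicity, read by XTT assay, with a stated time of 72 h (a higher number here means a weaker inhibitor, a lower number a stronger inhibitor), the value > 30000 nM, which is a limit of the assay and not a number.
Compound 2, `COc1ccc(OC)c(-c2cc(-c3ccc(C(=O)N(C)Cc4ccccc4)s3)on2)c1`, gives in this assay the value > 30000 nM, again a limit.
Compound 3, `CCCN(C)C(=O)c1ccc(-c2cc(C3=CC(=O)C=CC3=O)no2)s1`, gives in this assay the value > 30000 nM, also a limit.

Compound 3 therefore stands at the limit, with no number of its own; all three measured compounds sit at the same limit, as the evidence states: the limit of > 30000 nM in this assay, at which 3 of the 3 values shown sit. Compound 4, `CN(Cc1ccccc1)C(=O)c1ccc(-c2cc(C3=CC(=O)C=CC3=O)no2)s1`, has not yet been measured. It differs from compound 3 in one place: phenyl in place of ethyl on a saturated chain carbon bound to an amide-type nitrogen.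

Within the data shown here, only one measured step touches compound 3, and it is unreadable, since both of its ends are limits: a step that the two limits leave unreadable from compound 1 to compound 3. Compound 2 carries the same benzyl(methyl)amino group as compound 4 on a different core, and its value is likewise a limit, so nothing about the size of the present change can be read from it. No step bears on the change in a readable way, and no direction can be drawn from the numbers shown.

With every measured value at the limit, compound 4 is expected to remain there as well, and the step from compound 3 to compound 4 is estimated at a step that the limit leaves unreadable from compound 3 to compound 4. For compound 4 the estimate in this assay is 40000 nM, with a range from 10000 nM to 150000 nM.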

Compound 4, half-maximal inhibitory concentration: > 30000 nM
Compound 4 ended at the assay's limit; the forecaster's own chance of this, stated with the estimate: 80%; the middle value is on the limit's open side.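

None of the steps from compound 1, compound 2 or compound 3 to compound 4 can be read, since both ends of each step are limits and not numbers: the limit of > 30000 nM in this assay, at which 4 of the 4 values shown sit.

The compounds shown leave open how far apart these four compounds truly lie in this assay, and which change, if any, would give a measurable value.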